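Extending a Propyl Chain by One Carbon: What to Expect

The compounds below may be only part of what the source reports. "The series", "measured", "known", "first", "only" and "open" are said of these compounds alone.

Measured so far in an ADME assay on the whole organism with Oryza sativa as the target, tested at 0.1 uM; a higher number here means a weaker effect of the compound at the concentration tested, a lower number a stronger effect:
Compound 1, `Cc1ccc(NC(=O)N[C@H](C)c2ccccc2)cc1`, gives 100%.
Compound 2, `CC(C)c1ccc(NC(=O)N[C@H](C)c2ccccc2)cc1`, gives 99%.
Compound 3, `CCCc1ccc(NC(=O)N[C@H](C)c2ccccc2)cc1`, gives 33%.

Compound 3 stands lowest of the three numbers in this assay, and it lies beyond the scatter from both of the others: the step of a number 67 percentage points lower from compound 1 to compound 3 (beyond the scatter) and the step of a number 66 percentage points lower from compound 2 to compound 3 (beyond the scatter) are both large, whereas the step of a number 1 percentage points lower from compound 1 to compound 2 (within the scatter) is within the scatter. Compound 4, `CCCCc1ccc(NC(=O)N[C@H](C)c2ccccc2)cc1`, has not yet been measured. It differs from compound 3 by methyl in place of hydrogen on a saturated chain carbon, three bonds along the chain from an aromatic carbon. The step that bears most on this change is a number 67 percentage points lower from compound 1 to compound 3 (beyond the scatter), which also lengthened the same chain and went strongly downward, and a number 66 percentage points lower from compound 2 to compound 3 (beyond the scatter) points the same way. On that basis, compound 4 is expected either to move further down or to stay within the scatter of compound 3. The step from compound 3 to compound 4 in this assay is expected to be a number 13 percentage points lower from compound 3 to compound 4 (beyond the scatter). Compound 4 is therefore estimated at 20%, with a range from 0% to 45%.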

Compound 4, a percentage reported as activity, at one concentration (the size of the read-out at that concentration, not a potency): 100%
Beside the measured number, compound 4's estimate is 80 percentage points below it, outside the stated range (above it).
By their numbers in this assay, from the lowest: compound 3; then compounds 2, 1 and 4 (each within the scatter of the next).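

In this assay, lengthening propyl to butyl gives a number 67 percentage points higher from compound 3 to compound 4 (beyond the scatter) and so reverses the earlier drop rather than extending it. Butyl sits level with the other two groups, as shown by no change at the digits printed from compound 1 to compound 4 (within the scatter) and by a number 1 percentage points higher from compound 2 to compound 4 (within the scatter), which leaves propyl alone among the four groups shown with a low number, so one methyl three bonds along the chain from an aromatic carbon is enough to separate a clear effect from almost none. No supporting data are available to explain this sharp reversal. 

The compounds shown leave open whether the low number belongs to propyl alone or extends to a neighbouring chain length, which an ethyl or a pentyl group would help to settle. They also leave open whether a propyl chain ending in a hydroxyl or an amine would keep the effect seen with compound 3.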